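A few compounds are considered here, and "the series" means these few. Any claim that something is new, unique, unknown or untested is made for them only; others in the source may bear on it.

Measured so far:
Compound 1 `Cc1sc(N)c(C(=O)c2cccs2)c1C` — in an assay on CHO-K1 cells with adenosine receptor A1 (Homo sapiens) as the target (a lower number here means that less compound is needed, a higher number that more compound is needed for the effect), compound 1 gives 11200 nM.
Compound 2 `CCOC(=O)c1nn(-c2ccc(C(C)(C)C)cc2)c(=O)c2c(N)scc12` — in this assay compound 2 gives 9750 nM.

Both numbers are high, so both compounds need a fair amount of material before the effect shows. Compound 2 has the lower of the two numbers, but its distance to compound 1 is within the usual scatter, so no real difference between them can be claimed.

The next compound is compound 3 `CCOC(=O)c1nn(-c2ccc(O)cc2)c(=O)c2c(N)scc12`. It differs from compound 2 in one place: hydroxy in place of tert-butyl on an aromatic carbon. A small group with one hydrogen-bond donor and one hydrogen-bond acceptor stands where a bulky group with neither stood before.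

For the measured compounds named here, no two measured compounds here differ in a single place, so there is no step of this kind to lean on, and the two measured values point only to the weak range as a starting point. The expected step from compound 2 to compound 3 is therefore a 1.2-fold higher number from compound 2 to compound 3 (0.09 log units; within the scatter), which is hardly more than the scatter, with the direction open. Compound 3 is expected to give 12000 nM in this assay, within the range 3000 nM to 50000 nM.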

Compound 3, half-maximal effective concentration: 7100 nM
The estimate for compound 3 lay 1.7-fold (0.23 log units) above the measured number; the measured number falls inside the stated range.
By their numbers in this assay, from the lowest: compounds 3, 2 and 1 (each within the scatter of the next).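

For the compounds shown here, this pair is the first to differ in one place only, so it gives the first direct reading of a change on this aromatic carbon. In this assay, replacing tert-butyl with hydroxy gives a 1.4-fold lower number from compound 2 to compound 3 (0.14 log units; within the scatter), so this step cannot be told apart from repeat-measurement noise. At this position, then, a bulky group made of carbon alone and a single oxygen-bearing group that brings a hydrogen-bond donor and acceptor give numbers that cannot be separated, and both compounds remain in the high range; no independent measurement is available to explain this result.

A single step cannot show whether other groups on this aromatic carbon, such as an amine, a carboxylic acid or a longer chain, would give a number clearly apart from these two. As far as these compounds go, it also remains open whether a change elsewhere on the shared core, such as replacing the ethyl ester with a carboxylic acid, would produce a step beyond the scatter.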